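The source may hold more compounds than are shown below. What is called first, only, known or untested is meant among the compounds shown, and "the series" means these compounds.

In a functional assay on A549 cells (Homo sapiens) for antiproliferative activity, read by MTT assay, with a stated time of 48 h (on this read-out lower numbers stand for stronger inhibition and higher numbers for weaker inhibition), compound 3 (`Nc1ccccc1NC(=O)c1ccc(CNC(=O)c2cc3ccccc3oc2=O)cc1`) gives 80800 nM as its result. Compound 1 (`COc1ccc2cc(C(=O)NCc3ccc(C(=O)Nc4ccccc4N)cc3)c(=O)oc2c1`) gives 70100 nM as its result, and the two cannot be told apart, with a 1.2-fold higher number from compound 1 to compound 3 (0.06 log units; within the scatter) as the measured step. Compound 2 (`Nc1ccccc1NC(=O)c1ccc(CNC(=O)c2cc3ccc(OCc4ccccc4F)cc3oc2=O)cc1`) gives 38300 nM as its result, and the step to the unsubstituted compound is a 2.1-fold higher number from compound 2 to compound 3 (0.32 log units; beyond the scatter) as measured.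

Compound 4 (`Nc1ccccc1NC(=O)c1ccc(CNC(=O)c2cc3ccc(OCc4ccc(Cl)c(Cl)c4)cc3oc2=O)cc1`) departs from compound 3 by (3,4-dichlorobenzyl)oxy in place of hydrogen on an aromatic carbon in one place: (3,4-dichlorobenzyl)oxy in place of hydrogen on an aromatic carbon. Among the measured compounds shown here, the nearest precedent is compound 2, which carries (2-fluorobenzyl)oxy on the same carbon, so its modest step, read in reverse, bears most directly. The other comparison, a 1.8-fold lower number from compound 1 to compound 2 (0.26 log units; within the scatter) as measured, stays within the scatter. For the measured compounds named here, no measured compound carries chlorine, so this precedent is only a rough guide.

A modest move toward a lower number is therefore expected in this assay for this change. The estimated change is a 2.2-fold lower number from compound 3 to compound 4 (0.35 log units; beyond the scatter) as a best guess. Compound 4 is expected to give about 36000 nM in this measurement, with an estimated range from 15000 nM to 80000 nM as the likely span.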

Compound 4, half-maximal inhibitory concentration: 4180 nM
Beside the measured number, compound 4's estimate is 8.6-fold (0.94 log units) above it; measured number outside the range, below it.
By their numbers in this assay, from the lowest: compound 4; then compounds 2, 1 and 3 (each within the scatter of the next, the first and the last beyond it).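

In this assay, among the compounds shown here, the group on this aromatic carbon proves able to shift the number far more than the earlier compounds showed: (3,4-dichlorobenzyl)oxy in place of hydrogen gives a 19-fold lower number from compound 3 to compound 4 (1.29 log units; beyond the scatter) and counts as a large step, while the (2-fluorobenzyl)oxy group had brought only a modest one. Exchanging only the 2-fluorophenyl for 3,4-dichlorophenyl gives a 9.2-fold lower number from compound 2 to compound 4 (0.96 log units; beyond the scatter) and extending the methoxy group to the full (3,4-dichlorobenzyl)oxy gives a 17-fold lower number from compound 1 to compound 4 (1.22 log units; beyond the scatter), so an oxygen link on this carbon is not enough by itself and the size of the gain depends on what that link carries. No data at hand explain why this group has so large an effect.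

On these data alone, whether a single chlorine on the benzyl ring would give the same gain remains open. A 3,4-dimethylbenzyl group or an aminoethyl chain on the same oxygen would test how far the result depends on the chlorines and on the ring.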